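The source may hold more compounds than are shown below. What is called first, only, known or untested is meant among the compounds shown, and "the series" means these compounds.

Measured so far:
Compound 1, `CC(Oc1ccc(Oc2ccc(Cl)cc2)cc1)C(=O)Cn1nnc(-c2ccccc2)n1`: 6
Compound 2, `CC(Oc1ccc(Oc2ccc(C(F)(F)F)cc2)cc1)C(=O)Cn1nnc(-c2ccccc2)n1`: 6.2
Compound 3, `CC(Oc1ccc(Oc2ccc(Cl)cc2)cc1)C(=O)Cn1nnc(-c2ccc(Cl)cc2)n1`: 6.8

In a physicochemical assay for lipophilicity, read by HPLC, tested at 5 mM (a higher number here means a more lipophilic compound, a lower number a more polar compound), compound 1 gives 6 and compound 2 gives 6.2; the change between them is trifluoromethyl in place of chloro on an aromatic carbon and the step is a number 0.20 log units higher from compound 1 to compound 2 (within the scatter). Compound 3 differs from compound 1 by chloro in place of hydrogen on an aromatic carbon, a step of a number 0.80 log units higher from compound 1 to compound 3 (beyond the scatter). Compound 4, `CC(Oc1ccc(Oc2ccc(C(F)(F)F)cc2)cc1)C(=O)Cn1nnc(-c2ccc(Cl)cc2)n1`, has not been measured. It differs from compound 3 by trifluoromethyl in place of chloro on an aromatic carbon, the same change as from compound 1 to compound 2, made on a core that itself differs by the chloro of compound 3. Resting on the step of a number 0.20 log units higher from compound 1 to compound 2 (within the scatter) seen on the other core, the account expects a number 0.20 log units higher from compound 3 to compound 4 (within the scatter), a step within the scatter. Compound 4 is therefore estimated at 7, with a range of 6.6 to 7.4.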

Compound 4, partition coefficient: 7
Beside the measured number, compound 4's estimate shows no gap at the digits printed, within the range that was stated.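

In this assay the change from chloro to trifluoromethyl on the core of compound 3 gives a number 0.20 log units higher from compound 3 to compound 4 (within the scatter) and so matches a number 0.20 log units higher from compound 1 to compound 2 (within the scatter) on the core of compound 1. The other change also repeats, with a number 0.80 log units higher from compound 2 to compound 4 (beyond the scatter) matching a number 0.80 log units higher from compound 1 to compound 3 (beyond the scatter) in size, so the two changes carry from one core to the other across these four compounds. This rests on a single set of four, and no measurement given bears on why the steps agree.

The compounds shown leave open whether the same steps would hold for an amine or a carboxylic acid in that place. From the compounds shown here alone, a longer chain there is equally open.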